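Benzyl Ether Swap: Trifluoromethyl Out, Dichloro In

The source may report more compounds than this note shows. Statements on the series, on what has been measured and on what is new or still open speak of the compounds shown alone.

Three measured compounds share one core and differ only in the benzyl ether. Compound 1 `Cc1ccc(NC(=S)NC(=O)c2ccc(OCc3ccccc3F)cc2)cc1-c1nc2ccccc2[nH]1` gives 6440 nM in a functional assay on SW-620 cells (Homo sapiens) for inhibition, read by MTT assay, with a stated time of 48 h; a higher number here means a weaker inhibitor, a lower number a stronger inhibitor. Within the data shown here, compound 2 `Cc1ccc(NC(=S)NC(=O)c2ccc(OCc3ccc(Cl)cc3Cl)cc2)cc1-c1nc2ccccc2[nH]1` gives 57200 nM in this assay, and the only single-point step among measured compounds is an 8.9-fold higher number from compound 1 to compound 2 (0.95 log units; beyond the scatter). Compound 3 `Cc1ccc(NC(=O)NC(=O)c2ccc(OCc3ccc(C(F)(F)F)cc3)cc2)cc1-c1nc2ccccc2[nH]1` gives 15300 nM in this assay; of the three numbers it stands second highest, with compound 1 nearest and compound 2 furthest, both gaps beyond the scatter.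

Compound 4 `Cc1ccc(NC(=O)NC(=O)c2ccc(OCc3cccc(Cl)c3Cl)cc2)cc1-c1nc2ccccc2[nH]1` differs from compound 3 in one place: 2,3-dichlorophenyl in place of 4-(trifluoromethyl)phenyl on a saturated chain carbon bound to an oxygen on an aromatic ring. Among the measured compounds shown here, one measured step bears on this: from compound 1 to compound 2 a dichlorophenyl also entered at that place, although from a different leaving group and in compounds that differ from compound 3 elsewhere; that step read an 8.9-fold higher number from compound 1 to compound 2 (0.95 log units; beyond the scatter). For the measured compounds named here, no measured pair shows 4-(trifluoromethyl)phenyl giving way to a dichlorophenyl, so the expectation is looser than that single step. On this comparison the step is expected to be upward, about a 2.3-fold higher number from compound 3 to compound 4 (0.36 log units; beyond the scatter) in this assay. Compound 4 is therefore estimated at 35000 nM, within a range from 12000 nM to 100000 nM.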

Compound 4, half-maximal inhibitory concentration: 42100 nM
The estimate for compound 4 lay 1.2-fold (0.08 log units) below the measured number; the measured number falls inside the stated range.
By their numbers in this assay, from the lowest: compound 1; then compound 3; then compounds 4 and 2 (each within the scatter of the next).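

With a carbonyl in compounds 3 and 4 where compounds 1 and 2 carry a thiocarbonyl, the group on the saturated chain carbon still moves the number in this assay and the change reads a 2.8-fold higher number from compound 3 to compound 4 (0.44 log units; beyond the scatter) as a second upward step at this place, alongside an 8.9-fold higher number from compound 1 to compound 2 (0.95 log units; beyond the scatter) from the earlier pair. Both steps that bring in a dichlorophenyl therefore point the same way and neither of the measured steps goes against that, although the two steps start from different groups and bring in different dichlorophenyl groups, so the direction holds only for these compounds. The groups exchanged between compound 3 and compound 4 each hold one six-membered aromatic ring of carbon only, with no hydrogen-bond donors or acceptors and no net charge, and nothing shown here accounts for the rise.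

The compounds shown leave open whether the carbonyl and the thiocarbonyl read alike when the benzyl ether is held constant, since no pair differs in that place alone. They also leave open how a single chlorine, a methoxy group, an amine or a carboxylic acid on that aromatic ring would read in this assay.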